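A few compounds are considered here, and "the series" means these few. Any claim that something is new, unique, unknown or untested is made for them only; others in the source may bear on it.

Compound 1 `c1ccc(-c2ccc(Cn3cncc3CNc3cccc(-c4ccccc4)c3)cc2)cc1`: 10000 nM
Compound 2 `CC(C)OC(=O)c1ccc(NCc2cncn2Cc2ccc(-c3ccccc3)cc2)cc1-c1ccccc1`: > 10000 nM (a limit of the assay)
Compound 3 `O=C(OC1CCCCC1)c1ccc(NCc2cncn2Cc2ccc(-c3ccccc3)cc2)cc1-c1ccccc1`: > 10000 nM (a limit of the assay)

All three were tested in a toxicity assay on NIH3T3 cells (Mus musculus) for cytotoxicity, read by resazurin assay; on this read-out higher numbers stand for an effect only at larger amounts of compound and lower numbers for an effect already at smaller amounts. Compound 1 gives 10000 nM in this assay. For compound 3 the assay reports only a limit, > 10000 nM, so compound 3 sits at the upper boundary of what can be read, as one of the two values covered by the limit of > 10000 nM in this assay, at which 2 of the 3 values shown sit. Putting an ester in place of hydrogen gave a number no lower from compound 1 to compound 2 (the limit leaves the size open) and a number no lower from compound 1 to compound 3 (the limit leaves the size open); the exchange of the alcohol part gave a step that the two limits leave unreadable from compound 2 to compound 3. None of these steps has a readable size.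

Compound 4 `N#Cc1ccc(NCc2cncn2Cc2ccc(-c3ccccc3)cc2)cc1-c1ccccc1` differs from compound 3 by cyano in place of cyclohexyloxycarbonyl on an aromatic carbon. The hydrogen at this position in compound 1 gave 10000 nM. Compound 4 is therefore expected near 10000 nM, between 4000 nM and 30000 nM, an expected step of a number no higher from compound 3 to compound 4 (the limit leaves the size open), with a fair chance of only a limit being reported.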

Compound 4, half-maximal effective concentration: > 1000 nM
Compound 4: no number, only a limit (the forecaster's own chance of this, stated with the estimate: 55%); the middle value does not contradict the limit.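

Compound 4 gives only a limit, and none of its steps from compound 1, compound 2 or compound 3 can be read. The compounds shown leave open whether cyano or either ester in place of hydrogen changes the number in this assay at all.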